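Cytotoxicity of an imine series: compound 3 from compound 2

The source may report more compounds than this note shows. Statements on the series, on what has been measured and on what is new or still open speak of the compounds shown alone.

Measured compounds:
Compound 1, `Fc1ccccc1/C=N/c1sc2c(c1-c1nc3ccccc3s1)CCC2`: 394 ug/mL
Compound 2, `Clc1ccc(/C=N/c2sc3c(c2-c2nc4ccccc4s2)CCC3)c(Cl)c1`: 310 ug/mL

Within the data shown here, compound 2 is one of two compounds measured in an ADME assay on HepG2 cells (Homo sapiens) for cytotoxicity, read by MTT assay, with a stated time of 72 h; on this read-out higher numbers stand for lower toxicity in this test and lower numbers for higher toxicity in this test. In this assay, among the measured compounds shown here, compound 2 gives 310 ug/mL, and compound 1, the only other compound measured, gives 394 ug/mL; the two numbers are within the scatter of one another, as the step of a 1.3-fold lower number from compound 1 to compound 2 (0.10 log units; within the scatter) shows.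

Compound 3, `Oc1ccccc1/C=N/c1sc2c(c1-c1nc3ccccc3s1)CCC2`, has not yet been measured. It differs from compound 2 in one place: 2-hydroxyphenyl in place of 2,4-dichlorophenyl on a carbon with a double bond to nitrogen. For the measured compounds named here, the only measured step in this assay is a 1.3-fold lower number from compound 1 to compound 2 (0.10 log units; within the scatter), which also swaps one aryl group for another on the same carbon and stays within the scatter. No measured step exchanges halogen-bearing groups for a hydroxyphenyl group, so nothing shown points to a step beyond the scatter in either direction.

On that basis compound 3 is expected to give about 340 ug/mL in this assay, with a range from 170 ug/mL to 680 ug/mL. The estimated step of a 1.1-fold higher number from compound 2 to compound 3 (0.04 log units; within the scatter) is expected to remain within the scatter.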

Compound 3, half-maximal cytotoxic concentration: 156 ug/mL
Estimate against measurement, compound 3: 2.2-fold (0.34 log units) above; measured number outside the range, below it.
By their numbers in this assay, from the lowest: compounds 3, 2 and 1 (each within the scatter of the next, the first and the last beyond it).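

In this assay, among these compounds, this position shows its first step beyond the scatter: the single exchange of hydroxy in place of fluoro on an aromatic carbon gives a 2.5-fold lower number from compound 1 to compound 3 (0.40 log units; beyond the scatter) and so moves the reading, modestly, toward higher toxicity in this test. Among the compounds shown here, the exchange of 2,4-dichlorophenyl for 2-hydroxyphenyl on the same carbon gives a 2.0-fold lower number from compound 2 to compound 3 (0.30 log units; within the scatter) and does not separate the two compounds, so only the pair with the fluoro group shows that the group on this carbon can alter the reading. No measurement accompanies these numbers that would bear on why the hydroxy-bearing compound reads as it does.

The compounds shown leave open whether this shift belongs to the hydroxy group itself or would also follow from another group in its place, such as methoxy or an amine. They also leave open how the reading would respond if the whole aryl group on this carbon gave way to a pyridine ring or a short alkyl chain.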